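This account rests on a few compounds, and the source may have more. Where it says the series, first, only, none or still open, it means among the compounds named here.

In an ADME assay on HUVEC cells (Homo sapiens) for cytotoxicity, read by MTT assay, with a stated time of 72 h (a higher number here means a weaker inhibitor, a lower number a stronger inhibitor), the three measured compounds give:

compound 1 `O=C(O)CCC(=O)OCCCCCCSc1ccc([N+](=O)[O-])c2nonc12`: 740 nM
compound 2 `O=C(CCC(=O)OCCCCCCSc1ccc([N+](=O)[O-])c2nonc12)Nc1ccccc1F`: 840 nM
compound 3 `Cc1ccc(NC(=O)CCC(=O)OCCCCCCSc2ccc([N+](=O)[O-])c3nonc23)cc1`: 2340 nM

Compound 3 carries the highest number of the three, as a 3.2-fold higher number from compound 1 to compound 3 (0.50 log units; beyond the scatter) and a 2.8-fold higher number from compound 2 to compound 3 (0.44 log units; beyond the scatter) show, both modest steps. Compound 4 `COc1ccc(NC(=O)CCC(=O)OCCCCCCSc2ccc([N+](=O)[O-])c3nonc23)cc1` differs from compound 3 by methoxy in place of methyl on an aromatic carbon. Going by the values given here, none of the measured steps alters a substituent on the aryl ring itself; the nearest comparison is the exchange of the whole aryl group on the amide nitrogen, a 2.8-fold higher number from compound 2 to compound 3 (0.44 log units; beyond the scatter), while a 1.1-fold higher number from compound 1 to compound 2 (0.06 log units; within the scatter) stayed within the scatter. A swap of methyl for methoxy is a smaller change than either, so compound 4 is expected to move by a 1.2-fold lower number from compound 3 to compound 4 (0.07 log units; within the scatter), within the scatter. Compound 4 is therefore estimated at 2000 nM in this assay, with a range from 800 nM to 5000 nM.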

Compound 4, half-maximal inhibitory concentration: 1590 nM
Compound 4: middle estimate off by 1.3-fold (0.10 log units), on the high side; measured number inside the range.
By their numbers in this assay, from the lowest: compounds 1, 2, 4 and 3 (each within the scatter of the next, the first and the last beyond it).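

In this assay, going by these compounds alone, this is the first change on the aryl ring itself: methoxy in place of methyl, para to a large group, gives a 1.5-fold lower number from compound 3 to compound 4 (0.17 log units; within the scatter), so this position takes the swap without a step beyond the scatter. Unlike 4-methylphenyl, 4-methoxyphenyl in place of 2-fluorophenyl stays within the scatter, at a 1.9-fold higher number from compound 2 to compound 4 (0.28 log units; within the scatter), while (4-methoxyphenyl)amino in place of hydroxy still gives a 2.1-fold higher number from compound 1 to compound 4 (0.33 log units; beyond the scatter). Nothing available accounts for these readings. On these data alone, what a chlorine, a hydroxy group or a dimethylamino group would give on the same aromatic carbon stays open, as does the effect of a longer chain.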